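A few compounds are considered here, and "the series" means these few. Any claim that something is new, unique, unknown or untested is made for them only; others in the source may bear on it.

Of the compounds shown here, three with a shared core have been measured in a functional assay on HL-60 cells (Homo sapiens) for inhibition, read by MTT assay, with a stated time of 48 h, tested at 10 uM; a higher number here means more inhibition of growth at the concentration tested, a lower number less inhibition of growth. Compound 1 `Cc1oc2c([C@H]3CCN(C)C[C@H]3O)c(O)cc(O)c2c(=O)c1C(O)c1ccc(Cl)cc1`, with 4-chlorophenyl on a saturated chain carbon bound to an aromatic carbon and an oxygen on a saturated carbon, gives 2%. Compound 2 `COc1ccc(C(O)c2c(C)oc3c([C@H]4CCN(C)C[C@H]4O)c(O)cc(O)c3c2=O)cc1Br`, with 3-bromo-4-methoxyphenyl at that place, gives 23%. Compound 3 `Cc1oc2c([C@H]3CCN(C)C[C@H]3O)c(O)cc(O)c2c(=O)c1C(O)c1cccc(Cl)c1Cl`, with 2,3-dichlorophenyl there, gives 12%. Two steps fix its standing: the value falls clearly short only against one neighbour, a number 11 percentage points lower from compound 2 to compound 3 (beyond the scatter), while the other comparison gives a number 10 percentage points higher from compound 1 to compound 3 (within the scatter).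

The next compound is compound 4 `Cc1oc2c([C@H]3CCN(C)C[C@H]3O)c(O)cc(O)c2c(=O)c1C(O)c1ccc(F)cc1`, with 4-fluorophenyl in place of 2,3-dichlorophenyl at the same carbon: 4-fluorophenyl in place of 2,3-dichlorophenyl on a saturated chain carbon bound to an aromatic carbon and an oxygen on a saturated carbon. For the measured compounds named here, no measured step introduces 4-fluorophenyl. The closest guide is the step between the 4-chlorophenyl and 2,3-dichlorophenyl groups, a number 10 percentage points higher from compound 1 to compound 3 (within the scatter), since compound 4 resembles compound 1 in carrying one halogen at the 4 position of the ring. The larger step, a number 21 percentage points higher from compound 1 to compound 2 (beyond the scatter), involves a group absent here and bears on it little. The expected change is small and downward, within the scatter: a number 5 percentage points lower from compound 3 to compound 4 (within the scatter). For compound 4 the estimated value is 7%, with an expected range from 0% to 20%.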

Compound 4, percent growth inhibition at one concentration: 30%
For compound 4 the middle estimate is 23 percentage points below the measured one; measured number outside the range, above it.
By their numbers in this assay, from the lowest: compounds 1 and 3 (each within the scatter of the next); then compounds 2 and 4 (each within the scatter of the next).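

Fluoro in place of chloro on an aromatic carbon is a change of one halogen on the ring, yet in this assay it gives a number 28 percentage points higher from compound 1 to compound 4 (beyond the scatter) and so shows that this exchange alone can carry a step beyond the scatter at this position. The 4-fluorophenyl group also separates from the 2,3-dichlorophenyl group, with a number 18 percentage points higher from compound 3 to compound 4 (beyond the scatter), while against the 3-bromo-4-methoxyphenyl group the data give a number 7 percentage points higher from compound 2 to compound 4 (within the scatter), so a high value here does not depend on the larger ring substitution of compound 2, and compound 1 shows that a single halogen on the ring does not ensure one. Nothing at hand accounts for the difference between fluoro and chloro on this ring.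

As far as these compounds go, how a plain phenyl group or a 4-bromophenyl group at this carbon would compare with the 4-fluorophenyl group remains open, as does the effect of an amine or a carboxylic acid on the ring. Also open, from the compounds shown here alone, is whether the gap between the 4-chlorophenyl and 4-fluorophenyl groups would hold at other concentrations or in other cell lines.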